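From Fluoro to Trifluoromethyl: Expecting Compound 4

The compounds below may be only part of what the source reports. "The series", "measured", "known", "first", "only" and "open" are said of these compounds alone.

Four compounds share one core, and three of them appear in a functional assay on KB cells (Homo sapiens) for cytotoxicity, read by MTT assay, with a stated time of 72 h; on this read-out lower numbers stand for stronger inhibition and higher numbers for weaker inhibition. Compound 1 `COc1ccc(Nc2nc3ccccc3nc2S(=O)(=O)c2ccccc2)cc1` is recorded there as "not determined" (no result reported). Compound 2 `Nc1cccc(Nc2nc3ccccc3nc2S(=O)(=O)c2ccccc2)c1` gives 4290 nM. Compound 3 `O=S(=O)(c1ccccc1)c1nc2ccccc2nc1Nc1ccc(F)cc1` reports only a limit of the assay, > 50000 nM, so no single number is known for it. Compound 3 thus sits at the limit of > 50000 nM in this assay, at which 1 of the 3 values shown sits, while the other remaining entry carries no number at all. Among the compounds with values here, the one step between measured compounds, an at least 11-fold higher number from compound 2 to compound 3 (1.06 log units; beyond the scatter), is large.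

Compound 4 `O=S(=O)(c1ccccc1)c1nc2ccccc2nc1Nc1ccc(C(F)(F)F)cc1` differs from compound 3 in one place: trifluoromethyl in place of fluoro on an aromatic carbon. No measured step swaps one group for another at this position; the only step shown, an at least 11-fold higher number from compound 2 to compound 3 (1.06 log units; beyond the scatter), exchanged a different group on the ring and moved the number to the limit. That step gives little direct guidance, and compound 3 itself has no number from which a change could be measured. The expectation for compound 4 is a step of a number no higher from compound 3 to compound 4 (the limit leaves the size open), that is, no clear movement beyond the scatter. The estimate for compound 4 is 50000 nM, with a range from 10000 nM to 200000 nM, and a good chance that only a limit is reported again.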

Compound 4, half-maximal inhibitory concentration: > 50000 nM
Compound 4: no number, only a limit (the forecaster's own chance of this, stated with the estimate: 60%); the middle value sits exactly at the limit.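

Compound 3 and compound 4 both stop at a limit of the assay, so the size of the exchange of fluoro for trifluoromethyl on this aromatic carbon cannot be read. The comparison with compound 2 can still be read in this assay: replacing 3-aminophenyl with 4-(trifluoromethyl)phenyl gives an at least 11-fold higher number from compound 2 to compound 4 (1.06 log units; beyond the scatter), a large step that matches the one seen with 4-fluorophenyl, so two different groups at this spot now go with much weaker inhibition than compound 2 shows. As far as this read-out can tell, fluoro and trifluoromethyl cannot be told apart here, and the limit now holds a larger share of the set: the limit of > 50000 nM in this assay, at which 2 of the 4 values shown sit.

The compounds shown leave open whether the weaker inhibition follows from losing the amine of compound 2, from the different place of the new groups on the ring, or from both. A phenyl ring carrying an amine or a carboxylic acid in the place held by fluoro and trifluoromethyl could help separate these, and might give a number instead of a limit.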